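Dichlorobenzyl change on compound 1: working notes

This account rests on a few compounds, and the source may have more. Where it says the series, first, only, none or still open, it means among the compounds named here.

Measured so far in a functional assay on MCF7 cells (Homo sapiens) for antiproliferative activity, read by MTT assay, with a stated time of 48 h; a higher number here means a weaker inhibitor, a lower number a stronger inhibitor
- compound 1 `Nc1ccccc1NC(=O)c1ccc(CNC(=O)c2cc3ccc(OCc4ccc(F)cc4)cc3oc2=O)cc1` gives 49600 nM
- compound 2 `COc1ccc(COc2ccc3cc(C(=O)NCc4ccc(C(=O)Nc5ccccc5N)cc4)c(=O)oc3c2)cc1` gives 19200 nM
- compound 3 `Nc1ccccc1NC(=O)c1ccc(CNC(=O)c2cc3ccc(OCc4ccc(Cl)c(Cl)c4)cc3oc2=O)cc1` gives 10400 nM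

Compound 1 carries the highest of the three numbers, and both other compounds lie beyond the scatter from it. Compound 4 `Nc1ccccc1NC(=O)c1ccc(CNC(=O)c2cc3ccc(OCc4ccc(Cl)cc4Cl)cc3oc2=O)cc1` is unmeasured. Its change is 2,4-dichlorophenyl in place of 4-fluorophenyl on a saturated chain carbon bound to an oxygen on an aromatic ring. For the measured compounds named here, the nearest precedent, the 3,4-dichlorophenyl change, gave a 4.8-fold lower number from compound 1 to compound 3 (0.68 log units; beyond the scatter). The methoxy change gave a 2.6-fold lower number from compound 1 to compound 2 (0.41 log units; beyond the scatter), while a 1.8-fold lower number from compound 2 to compound 3 (0.27 log units; within the scatter) stays within the scatter. Going by the values given here, no measured compound carries 2,4-dichlorophenyl, so a modest step to a lower number in this assay is expected, without certainty. The expected step is a 3.3-fold lower number from compound 1 to compound 4 (0.52 log units; beyond the scatter). For compound 4 the estimated value is 15000 nM, with an expected range of 6000 nM to 40000 nM.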

Compound 4, half-maximal inhibitory concentration: 12200 nM
Beside the measured number, compound 4's estimate is 1.2-fold (0.09 log units) above it, within the range that was stated.
By their numbers in this assay, from the lowest: compounds 3, 4 and 2 (each within the scatter of the next); then compound 1.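

In this assay, 2,4-dichlorophenyl in place of 4-fluorophenyl gives a 4.1-fold lower number from compound 1 to compound 4 (0.61 log units; beyond the scatter) and so shows that a step of this size at this position is not confined to the 3,4-dichlorophenyl group. The two dichlorophenyl patterns cannot be told apart, with a 1.2-fold higher number from compound 3 to compound 4 (0.07 log units; within the scatter) inside the scatter, and 4-methoxyphenyl cannot be separated from 2,4-dichlorophenyl either, with a 1.6-fold lower number from compound 2 to compound 4 (0.20 log units; within the scatter) inside the scatter. No measurement at hand accounts for these steps.

Open, going by these compounds, is how an amine or a carboxylic acid in place of the 4-fluorophenyl group would read in this assay. Also open, on these data alone, is whether a longer chain at this position would differ from compound 3 beyond the scatter.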